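Swapping an Octyl Chain for a Trifluoromethylphenyl Ring

The source may report more compounds than this note shows. Statements on the series, on what has been measured and on what is new or still open speak of the compounds shown alone.

Compound 1 `CCOC(=O)C1=Cc2ccccc2OC1(OCc1cn(CC(=O)Nc2cccc(F)c2)nn1)C(F)(F)F` and compound 2 `CCCCCCCCn1cc(COC2(C(F)(F)F)Oc3ccccc3C=C2C(=O)OCC)nn1` share one core and differ at a single point. In a functional assay on HeLa cells (Homo sapiens) for inhibition, read by MTT assay, with a stated time of 24 h (a lower number here means a stronger inhibitor, a higher number a weaker inhibitor), compound 1 gives only a limit, > 150000 nM. Compound 2 likewise gives only a limit in this assay, namely > 150000 nM. Going by the values given here, the one measured step, a step that the two limits leave unreadable from compound 1 to compound 2, cannot be sized, because both of its ends sit at the limit of > 150000 nM in this assay, at which 2 of the 2 values shown sit. Compound 2 therefore stands at the limit of this assay, with no number of its own to rank it.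

Compound 3 `CCOC(=O)C1=Cc2ccccc2OC1(OCc1cn(-c2cccc(C(F)(F)F)c2)nn1)C(F)(F)F` differs from compound 2 by 3-(trifluoromethyl)phenyl in place of octyl on an aromatic nitrogen. Among the compounds with values here, no measured step covers this exchange of an octyl chain for a 3-(trifluoromethyl)phenyl ring on the aromatic nitrogen, and the only measured step shows two compounds that both fail to reach a readable value. On these numbers alone, compound 3 is expected to stay close to the limit as well, with an estimated value of 200000 nM in this assay, somewhere between 50000 nM and 1000000 nM. The expected step, a step that the limit leaves unreadable from compound 2 to compound 3, is thus estimated to lie within the scatter, in no clear direction.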

Compound 3, half-maximal inhibitory concentration: > 150000 nM
Compound 3: no number, only a limit (the forecaster's own chance of this, stated with the estimate: 85%); the middle value is on the limit's open side.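

Compound 3 also gives only a limit, so neither the step from compound 2 to compound 3 nor the step from compound 1 to compound 3 can be read, because all the compounds share the same limit: the limit of > 150000 nM in this assay, at which 3 of the 3 values shown sit.

The compounds shown leave open whether any group on the aromatic nitrogen of the shared core gives a readable value in this assay.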